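Benzyl for tert-butyl on compound 2: working notes

The compounds below may be only part of what the source reports. "The series", "measured", "known", "first", "only" and "open" are said of these compounds alone.

In an ADME assay on liver for metabolic stability, with Liver microsome (Homo sapiens) as the target, read by LC-MS, using microsomes (a higher number here means faster removal of the compound, a lower number slower removal), the measured compounds are:
- compound 1 `CC(C)(C)[C@@H](O)C(=O)N1C[C@@H]2C[C@@H]2[C@H]1C(=O)NCc1cc(Cl)ccc1-n1cnnn1` gives < 15 mL.min-1.g-1 as a limit of the assay
- compound 2 `CC(C)(C)[C@@H](O)C(=O)N1C[C@H]2C[C@H]2[C@H]1C(=O)NCc1cc(Cl)ccc1-n1cnnn1` gives 22 mL.min-1.g-1 as a true number

Among the compounds with values here, compound 2 carries the only true number so far. Compound 3 `O=C(NCc1cc(Cl)ccc1-n1cnnn1)[C@@H]1[C@@H]2C[C@@H]2CN1C(=O)[C@H](O)Cc1ccccc1` has benzyl in place of tert-butyl on a saturated chain carbon bound to a carbonyl carbon and an oxygen on a saturated carbon and otherwise matches compound 2. Within the data shown here, the one measured step of an at least 1.4-fold higher number from compound 1 to compound 2 (0.16 log units; that floor lies within the scatter) has a floor within the scatter and bears little on this swap, given the fact that compounds 1 and 2 differ only in the configuration as drawn and no measured change at this side chain. Starting from compound 2 at 22 mL.min-1.g-1 a modest rise in this assay is expected, with wide uncertainty. The expected size is a 1.7-fold higher number from compound 2 to compound 3 (0.24 log units; within the scatter) and remains only an estimate. For compound 3 the estimated value is 38 mL.min-1.g-1 with an expected range of 17 mL.min-1.g-1 to 85 mL.min-1.g-1.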

Compound 3, intrinsic clearance in microsomes: 74 mL.min-1.g-1
Compound 3: the middle estimate sits 1.9-fold (0.29 log units) below what was measured; the measured number falls inside the stated range.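

In this assay, this position gives its first measured change: a 3.4-fold higher number from compound 2 to compound 3 (0.53 log units; beyond the scatter). The earlier pair differs only in configuration as drawn, whereas this step lies beyond the scatter and shows that the read-out responds to the group on a saturated chain carbon bound to a carbonyl carbon and an oxygen on a saturated carbon. Nothing measured here accounts for the size of the rise.

A single swap leaves open whether the rise goes with the aromatic ring of benzyl, a question on which cyclohexylmethyl at the same place would bear. Also open, on these data alone, is how benzyl reads on the core of compound 1, whose value is a limit of the assay.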